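Swapping pyridin-4-yl for 4-cyanophenyl on a second core

The source may report more compounds than this note shows. Statements on the series, on what has been measured and on what is new or still open speak of the compounds shown alone.

Measured so far in a functional assay on BMDM cells (Mus musculus, strain C57BL/6) for inhibition, with a stated time of 2 days; a higher number here means a weaker inhibitor, a lower number a stronger inhibitor:
Compound 1 `N#Cc1ccc(-c2cn(CC(=O)Nc3nc4ccccc4s3)nn2)cc1`: > 30000 nM, a limit of the assay
Compound 2 `O=C(Cn1cc(-c2ccncc2)nn1)Nc1nc2ccccc2s1`: 50 nM
Compound 3 `CCOC(=O)c1sc(NC(=O)Cn2cc(-c3ccncc3)nn2)nc1C`: 120 nM

Compound 2 and compound 1 share one core and differ in a single place: 4-cyanophenyl in place of pyridin-4-yl on an aromatic carbon. This change gives an at least 600-fold higher number from compound 2 to compound 1 (2.77 log units; beyond the scatter), and the number for compound 1 is only a limit, (the limit of > 30000 nM in this assay, at which 1 of the 3 values shown sits). Compound 3 rests on a different core; the difference between the two cores is not broken down here. In this assay compound 3 gives a higher number than compound 2, both being real numbers rather than limits. Compound 4 `CCOC(=O)c1sc(NC(=O)Cn2cc(-c3ccc(C#N)cc3)nn2)nc1C` is not yet measured; it differs from compound 3 by the same change, made at the same place: 4-cyanophenyl in place of pyridin-4-yl on an aromatic carbon. The expected step is a 250-fold higher number from compound 3 to compound 4 (2.40 log units; beyond the scatter), resting on the one earlier case of this change, an at least 600-fold higher number from compound 2 to compound 1 (2.77 log units; beyond the scatter). Compound 4 is therefore estimated at 30000 nM, between 3000 nM and 100000 nM, with a fair chance that only a limit is reported.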

Compound 4, half-maximal inhibitory concentration: 310 nM
Compound 4: middle estimate off by 97-fold (1.99 log units), on the high side; measured number below the stated range.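

In this assay, 4-cyanophenyl in place of pyridin-4-yl still gives a weaker inhibitor on the core of compound 3, but the loss is only modest, with a 2.6-fold higher number from compound 3 to compound 4 (0.41 log units; beyond the scatter). Going by these compounds, the direction of the change holds on both cores, while its size does not carry over from one core to the other: the same change on two cores in this assay, an at least 600-fold higher number (2.77 log units; beyond the scatter) from compound 2 to compound 1 and a 2.6-fold higher number (0.41 log units; beyond the scatter) from compound 3 to compound 4, at least 230-fold (2.36 log units) apart, beyond the scatter of two such steps Compound 1 gives > 30000 nM, which is a limit of the assay and not a number, so the true size of the earlier step stays unknown, and two cores cannot show which feature of a core sets the size of the step.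

On these data alone, it remains open whether a carboxylic acid or a primary amide in place of the ethyl ester of compound 3 would keep the step this small. As far as these compounds go, it is also open whether a different group on the phenyl ring, such as an aminomethyl group in place of the nitrile, would behave like 4-cyanophenyl on either core.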